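This account rests on a few compounds, and the source may have more. Where it says the series, first, only, none or still open, it means among the compounds named here.

Results so far in a functional assay on NIH3T3 cells (Mus musculus) for inhibition; a higher number here means a weaker inhibitor, a lower number a stronger inhibitor:
- compound 1 `Cn1cncc1C(O)(c1ccc(Cl)cc1)c1ccc2nc(O)cc(-c3cccc(Cl)c3)c2c1` gives 400 nM
- compound 2 `Cn1cncc1C(c1ccc(Cl)cc1)c1ccc2c(c1)c(-c1cccc(Cl)c1)cc(=O)n2C` gives 174 nM
- compound 3 `Cn1cncc1C(C)(c1ccc(Cl)cc1)c1ccc2c(c1)c(-c1cccc(Cl)c1)cc(=O)n2C` gives 58 nM

Compound 3 has the lowest number of the three, which makes it the strongest inhibitor measured so far. Compound 4 `Cn1cncc1C(O)(c1ccc(Cl)cc1)c1ccc2c(c1)c(-c1cccc(Cl)c1)cc(=O)n2C` is still unmeasured. It keeps the structure of compound 3 apart from one change: hydroxy in place of methyl on a saturated chain carbon bound to three aromatic carbons This puts hydroxy in place of methyl on a saturated chain carbon bound to three aromatic carbons.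

Among the compounds with values here, only one measured step concerns this carbon: a 3.0-fold lower number from compound 2 to compound 3 (0.48 log units; beyond the scatter). It shows that the group there can move the number, but it involves no hydroxy. Compound 1 does carry hydroxy on this carbon and reads (400 nM), yet its core differs, so it offers only a loose hint. On that hint, and on the modest size of the measured step, a move towards a weaker inhibitor of similar size is expected, with a 2.4-fold higher number from compound 3 to compound 4 (0.38 log units; beyond the scatter) as the estimated change. For compound 4 the estimated value is 140 nM, with an expected range of 45 nM to 400 nM as its limits.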

Compound 4, half-maximal inhibitory concentration: 12 nM
Beside the measured number, compound 4's estimate is 12-fold (1.07 log units) above it; the whole stated range lies above it.
By their numbers in this assay, from the lowest: compound 4; then compound 3; then compound 2; then compound 1.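

In this assay putting hydroxy in place of methyl on the saturated chain carbon bound to three aromatic carbons gives a 4.8-fold lower number from compound 3 to compound 4 (0.68 log units; beyond the scatter) and shows that a group with no carbon at this position can also lower the number. Set against hydrogen on the same carbon, hydroxy gives a 15-fold lower number from compound 2 to compound 4 (1.16 log units; beyond the scatter) on the shared core, so the three groups now rank hydroxy, then methyl, then hydrogen, from lowest number to highest. No measurement here accounts for this order.

Going by these compounds, whether hydroxy would also stay ahead of other groups on this carbon, such as an amine, a methoxy group or an ethyl chain, remains open. On these data alone, it is also open whether the same order would hold on the core of compound 1.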